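The compounds below may be only part of what the source reports. "The series", "measured", "known", "first", "only" and "open" are said of these compounds alone.

The measured compounds, each in an assay on NIH3T3 cells with Urotensin-2 receptor (Homo sapiens) as the target; a lower number here means that less compound is needed, a higher number that more compound is needed for the effect:

Compound 1, `CN(C)CCC(OC(=O)c1cn(C)c2ccccc12)c1ccc(Cl)cc1`, gives 1510 nM.
Compound 2, `COc1ccc(C(=O)OC(CCN(C)C)c2ccc(Cl)cc2)cc1`, gives 2190 nM.
Compound 3, `CN(C)CCC(OC(=O)c1ccc(C(F)(F)F)cc1)c1ccc(Cl)cc1`, gives 1740 nM.

All three share one core and differ only in the group on the aromatic ring of the ester. Compound 3 sits between the other two, and its gaps to compound 1 and to compound 2 are both within the scatter, so no order among the three can be read from these numbers. Within the data shown here, the only single-point step measured so far, a 1.3-fold lower number from compound 2 to compound 3 (0.10 log units; within the scatter), was likewise within the scatter.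

Compound 4, `CN(C)CCC(OC(=O)c1ccc(-c2ccccc2)cc1)c1ccc(Cl)cc1`, carries phenyl in place of trifluoromethyl on an aromatic carbon, in the place described as para to a large group. Among the measured compounds shown here, no measured step swaps in a ring at this position; the one change tried there, from methoxy to trifluoromethyl, left the number essentially unchanged. On that thin basis, the step from compound 3 to compound 4 in this assay is expected to be a 1.2-fold lower number from compound 3 to compound 4 (0.06 log units; within the scatter), that is, no shift beyond the scatter. Compound 4 is therefore estimated at 1500 nM, with a range from 500 nM to 5000 nM.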

Compound 4, half-maximal effective concentration: 525 nM
The estimate for compound 4 lay 2.9-fold (0.46 log units) above the measured number, and the stated range covers the measured number.
By their numbers in this assay, from the lowest: compound 4; then compounds 1, 3 and 2 (each within the scatter of the next).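

In this assay, among these compounds, putting a ring at this place, para to a large group, gives the first steps beyond the scatter: a 3.3-fold lower number from compound 3 to compound 4 (0.52 log units; beyond the scatter) and a 4.2-fold lower number from compound 2 to compound 4 (0.62 log units; beyond the scatter). The swap of methoxy for trifluoromethyl, a 1.3-fold lower number from compound 2 to compound 3 (0.10 log units; within the scatter), had stayed within the scatter, so this position does respond to what it carries, at least when phenyl enters. No measurement at hand bears on the reason for these steps.

Among the compounds shown, phenyl is the only ring at this place, and one compound cannot establish a trend across rings. Going by these compounds, it remains open whether a longer chain or an amine here would lower the number as phenyl does, or whether the shift needs an aromatic ring at all.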